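The compounds below may be only part of what the source reports. "The series", "measured", "known", "first", "only" and "open" are said of these compounds alone.

Of the compounds shown here, two have been measured in a functional assay on the whole organism with Mus musculus as the target, in the writhing test; a higher number here means that more compound is needed for the effect, a lower number that less compound is needed. Compound 1 (`FC(F)(F)CCSc1nsnc1[C@@H]1CN2CCC[C@@H]1C2`) gives 0.1 mg/kg in this assay, a clean number at a low dose. Compound 2 (`FC(F)(F)CCCSc1nsnc1[C@@H]1CN2CCC[C@H]1C2`) gives > 10 mg/kg, and this is a limit of the assay and not a number. It sits at the limit of > 10 mg/kg in this assay, at which 1 of the 2 values shown sits, so compound 2 has no exact position on the scale.

Compound 3 (`FC(F)(F)CCCSc1nsnc1[C@@H]1CN2CCC[C@@H]1C2`) is the next to be read against compound 2. Among the measured compounds shown here, the two compounds have the same atoms and bonds, and the only change is in the drawn configuration: the two compounds have the same atoms and bonds; at least one stereo element is drawn with a configuration in one of them and without one in the other: 1 of 3 stereo elements differ; a stereocentre at a saturated ring carbon is drawn R in compound 2 and S in compound 3. A stereocentre at a saturated ring carbon is drawn R in compound 2 and S in compound 3.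

For the measured compounds named here, no measured step between related compounds is available to size this change. With compound 2 at a limit, the only open direction is toward a lower dose, and a step well beyond the scatter is expected. That expectation leans on compound 1, which reaches 0.1 mg/kg. Some caution remains, and a result at the limit cannot be excluded.

The step expected is an at least 20-fold lower number from compound 2 to compound 3 (1.30 log units; beyond the scatter). In this assay the estimate for compound 3 is 0.5 mg/kg, with an expected range from 0.06 mg/kg to 5 mg/kg.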

Compound 3, dose for half-maximal effect: 0.35 mg/kg
Compound 3: the middle estimate sits 1.4-fold (0.15 log units) above what was measured; the measured number falls inside the stated range.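

In this assay the drawn configuration at one saturated ring carbon turns out to matter greatly for this thioether series, as it carries an at least 28-fold lower number from compound 2 to compound 3 (1.45 log units; beyond the scatter), and the only structural difference behind that step is this: the fact that one of compounds 2 and 3 is drawn with a defined configuration and the other without, at the place where they differ. The true size of the step may be larger, since compound 2 stands at a limit of the assay and not at a number: the limit of > 10 mg/kg in this assay, at which 1 of the 3 values shown sits. With the configuration of compound 1 kept, the side chain has a modest but real influence, as 2,2,2-trifluoroethyl in place of trifluoromethyl on a saturated chain carbon, two bonds along the chain from a sulfur, gives a 3.5-fold higher number from compound 1 to compound 3 (0.54 log units; beyond the scatter).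

The compounds shown leave open whether the configuration has as large an effect with the shorter chain of compound 1, and whether the dose keeps rising as the chain grows or would change with a longer chain or with an amine at its end. They also leave open how an oxygen in place of the sulfur would read in this assay, and through what route the configuration acts in the whole animal.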